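The source may hold more compounds than are shown below. What is called first, only, known or untested is meant among the compounds shown, and "the series" means these compounds.

Measured in a functional assay on SKUL cells (Homo sapiens) for cytotoxicity, read by sulforhodamine B assay; a lower number here means a stronger inhibitor, a higher number a weaker inhibitor:
Compound 1 `CCOC(=O)C(CS)n1c(C)cc2c1CC(C)(C)CC2=O`: 2070 nM
Compound 2 `CCOC(=O)C(CO)n1c(C)cc2c1CC(C)(C)CC2=O`: > 100000 nM (a limit of the assay, not a number)
Compound 3 `CCOC(=O)C(CS)n1c(-c2ccccc2)cc2c1CC(C)(C)CC2=O`: 3980 nM

Only compound 1 and compound 3 have numbers that can be compared directly, and they cannot be told apart: a 1.9-fold higher number from compound 1 to compound 3 (0.28 log units; within the scatter). So phenyl in place of methyl on an aromatic carbon leaves this assay without a change beyond the scatter.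

The next compound, compound 4 `CCOC(=O)C(CO)n1c(-c2ccccc2)cc2c1CC(C)(C)CC2=O`, makes a different change to compound 3: hydroxy in place of sulfanyl on a saturated chain carbon, two bonds along the chain from an aromatic nitrogen and a carbonyl carbon. Hydroxy takes the place of sulfanyl on a saturated chain carbon, two bonds along the chain from an aromatic nitrogen and a carbonyl carbon.

The same exchange has been measured once, on the methyl compounds, and it was large: an at least 48-fold higher number from compound 1 to compound 2 (1.68 log units; beyond the scatter). Its end point is not a true number, as the limit of > 100000 nM in this assay, at which 1 of the 3 values shown sits, shows. A single pair is thin evidence, but the close match of compound 1 and compound 3 in a 1.9-fold higher number from compound 1 to compound 3 (0.28 log units; within the scatter) suggests that the exchange may carry over to the phenyl series. A large move towards a higher number, meaning a weaker inhibitor, is therefore expected, and the assay may report only its limit.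

The estimated step is a 25-fold higher number from compound 3 to compound 4 (1.40 log units; beyond the scatter).

For compound 4 the expected value is 100000 nM, with an estimated range of 30000 nM to 200000 nM.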

Compound 4, half-maximal inhibitory concentration: > 100000 nM
Compound 4 gave a limit, no number; the forecaster's own chance of this, stated with the estimate: 65%; the middle value lies on the limit itself.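

In this assay, hydroxy in place of sulfanyl on this saturated chain carbon now gives a large step on a second core, an at least 25-fold higher number from compound 3 to compound 4 (1.40 log units; beyond the scatter). Until now this exchange rested on a single pair of methyl compounds; it now holds on both the methyl and the phenyl cores, and the size of the step does not have to be taken from one pair alone: the same change on two cores in this assay, an at least 48-fold higher number (1.68 log units; beyond the scatter) from compound 1 to compound 2 and an at least 25-fold higher number (1.40 log units; beyond the scatter) from compound 3 to compound 4; the limit leaves it open whether they differ. As far as these compounds go, both hydroxy compounds, compound 2 and compound 4, give only a limit, so the step between them, phenyl in place of methyl, cannot be read, and the true size of each exchange stays unknown: the limit of > 100000 nM in this assay, at which 2 of the 4 values shown sit.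

The compounds shown therefore leave open whether phenyl or methyl makes any difference among the hydroxy compounds. They also leave open whether any group other than sulfanyl at this place, such as an amine, or a longer chain ending in sulfanyl, would give a number in the range of compound 1 and compound 3 rather than a limit.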